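This account rests on a few compounds, and the source may have more. Where it says the series, first, only, none or still open, it means among the compounds named here.

The series shares the core of compound 1, structure `C=C(C)C(=O)N(Cc1ccc(OC)c(O)c1)c1cc(OC)c(OC)c(OC)c1`. In a functional assay on MGC-803 cells (Homo sapiens) for inhibition, read by MTT assay, with a stated time of 48 h (a higher number here means a weaker inhibitor, a lower number a stronger inhibitor), compound 1 gives 390 nM. Compound 2, structure `COc1cc(NCc2ccc(Br)cc2)cc(OC)c1OC`, differs in more than one place and carries no carbonyl on the nitrogen. In this assay compound 2 reaches only the limit of the assay, > 80000 nM, and not a number. Going by the values given here, compound 1 thus stands as the single numeric value in this assay, the other entry being (the limit of > 80000 nM in this assay, at which 1 of the 2 values shown sits). Among the compounds with values here, no pair of measured compounds differs in one place, so no measured step is available.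

Compound 3, structure `CCC(=O)N(Cc1ccc(OC)c(O)c1)c1cc(OC)c(OC)c(OC)c1`, is not yet measured in this assay. It differs from compound 1 as follows: ethyl in place of 1-methylethenyl on a carbonyl carbon. The change removes the one double bond outside aromatic rings that compound 1 carries on the carbonyl carbon, and adds nothing in donors or acceptors. The expected step from compound 1 to compound 3 in this assay is a loss of potency beyond the usual scatter, a 6.4-fold higher number from compound 1 to compound 3 (0.81 log units; beyond the scatter). On that basis compound 3 is estimated at 2500 nM in this assay, with a range from 700 nM to 10000 nM.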

Compound 3, half-maximal inhibitory concentration: 50 nM
Beside the measured number, compound 3's estimate is 50-fold (1.70 log units) above it; measured number below the stated range.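

At the position on a carbonyl carbon whose other neighbour is an amide-type nitrogen, the double bond of 1-methylethenyl is not needed for activity on the shared core: in this assay, ethyl in its place gives a 7.8-fold lower number from compound 1 to compound 3 (0.89 log units; beyond the scatter), a modest gain beyond the scatter. Going by these compounds alone, this is the first reading of this position, as compound 2 carries no carbonyl on the nitrogen and differs from compound 1 in more than one place. The swap removes the double bond and also takes the group from 3 heavy atoms to 2, so this single step does not separate the two changes, and nothing shown gives a cause for it.

Still open, from the compounds shown here alone, is which of the two changes carries the gain, a question that 1-methylethyl, the saturated match of the group that leaves, would address on the same core. Also open, going by these compounds, is how far the position tolerates other groups on the carbonyl carbon, such as methyl, a longer propyl or butyl chain, or a cyclopropyl ring, as one step sets no trend.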